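Ring size change at the amino substituent on the core

The source may report more compounds than this note shows. Statements on the series, on what has been measured and on what is new or still open speak of the compounds shown alone.

Among the compounds with values here, compound 2 `CC(C(=O)NCc1ccc(C(F)(F)F)nc1N1CCCC1)c1ccc(NS(C)(=O)=O)c(F)c1` gives 0.6 nM in a functional assay on CHO-K1 cells for antagonist activity at transient receptor potential cation channel subfamily V member 1 (Homo sapiens), read by FLIPR (on this read-out lower numbers stand for stronger inhibition and higher numbers for weaker inhibition), the higher of the two numbers so far; compound 1 `CCCN(CCC)c1nc(C(F)(F)F)ccc1CNC(=O)C(C)c1ccc(NS(C)(=O)=O)c(F)c1` gives 0.2 nM. Within the data shown here, the only step through this position runs from compound 1 to compound 2: a 3.0-fold higher number from compound 1 to compound 2 (0.48 log units; beyond the scatter). Compound 3 `CC(C(=O)NCc1ccc(C(F)(F)F)nc1N1CC=CCC1)c1ccc(NS(C)(=O)=O)c(F)c1` differs from compound 2 by a group of 6 heavy atoms (5 carbon, 1 nitrogen; one six-membered non-aromatic ring with 1 hetero atom) in place of a group of 5 heavy atoms (4 carbon, 1 nitrogen; one five-membered non-aromatic ring with 1 hetero atom), on an aromatic carbon. Among the measured compounds shown here, no measured step covers a change of ring size at this position; the one step that bears on it, a 3.0-fold higher number from compound 1 to compound 2 (0.48 log units; beyond the scatter), shows that reshaping the amino substituent moved the number only modestly. The expectation for compound 3 is therefore a step of a 1.2-fold lower number from compound 2 to compound 3 (0.08 log units; within the scatter) in this assay, not clearly beyond the scatter in either direction. Compound 3 is thus estimated at 0.5 nM in this assay, with an expected range from 0.15 nM to 2 nM.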

Compound 3, inhibition constant: 0.3 nM
Estimate against measurement, compound 3: 1.7-fold (0.22 log units) above; the measured number falls inside the stated range.
By their numbers in this assay, from the lowest: compounds 1, 3 and 2 (each within the scatter of the next, the first and the last beyond it).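

In this assay, within the data shown here, the first change of ring size at this position gives a 2.0-fold lower number from compound 2 to compound 3 (0.30 log units; within the scatter), and replacing the open-chain dipropylamino group with the six-membered ring gives a 1.5-fold higher number from compound 1 to compound 3 (0.18 log units; within the scatter). Compound 3 therefore stands within the scatter of both neighbours, even though the step that separates them, a 3.0-fold higher number from compound 1 to compound 2 (0.48 log units; beyond the scatter), lies beyond it, so the three amino substituents shown do not fall into two clearly separate groups. Nothing on hand gives a reason for these numbers.

In compound 3 the larger ring and the double bond enter together, so piperidin-1-yl, the saturated six-membered ring, is what would tell them apart. Going by these compounds, whether a ring with a second hetero atom, such as morpholin-4-yl, stays within this narrow range also remains open.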